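Lipoamide-triazole coumarin series: substituent on the lactone ring

The compounds below may be only part of what the source reports. "The series", "measured", "known", "first", "only" and "open" are said of these compounds alone.

Measured so far:
- Compound 1 `O=C(CCCCC1CCSS1)NCc1cn(CCCOc2ccc3ccc(=O)oc3c2)nn1`: in a functional assay on PC-12 cells (Rattus norvegicus) for cytotoxicity, read by MTT assay, with stated times of 3 h and 2 h, tested at 5 uM (a lower number here means a weaker effect, a higher number a stronger effect of the compound at the concentration tested), compound 1 gives 39.2%
- Compound 2 `CCOC(=O)c1cc2ccc(OCCCn3cc(CNC(=O)CCCCC4CCSS4)nn3)cc2oc1=O`: compound 2 gives 32.4%
- Compound 3 `O=C(CCCCC1CCSS1)NCc1cn(CCCOc2ccc3cc(C(=O)O)c(=O)oc3c2)nn1`: compound 3 gives 57%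

Compound 1 stands second highest of the three numbers. Its nearest neighbour is compound 2, reached by ethoxycarbonyl in place of hydrogen on an aromatic carbon, a step of a number 6.8 percentage points lower from compound 1 to compound 2 (within the scatter). The furthest is compound 3, reached by carboxy in place of hydrogen on the same aromatic carbon, a step of a number 17.8 percentage points higher from compound 1 to compound 3 (beyond the scatter). From compound 2 to compound 3, hydrogen in place of ethyl on an oxygen next to a carbonyl group gives a number 24.6 percentage points higher from compound 2 to compound 3 (beyond the scatter).

Compound 4 `COc1ccc(-c2cc3ccc(OCCCn4cc(CNC(=O)CCCCC5CCSS5)nn4)cc3oc2=O)cc1` is not yet measured. It differs from compound 1 by 4-methoxyphenyl in place of hydrogen on an aromatic carbon.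

Both measured steps from compound 1 change the same aromatic carbon and so bear on this one. The only gain beyond the scatter came with the carboxy of compound 3; the neutral ethoxycarbonyl of compound 2 stayed within the scatter. The entering group here is neutral, so the closer precedent is compound 2, and no step beyond the scatter is expected; the expected step is a number 1.2 percentage points lower from compound 1 to compound 4 (within the scatter). Compound 4 is therefore estimated at 38%, with a range from 24% to 52%.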

Compound 4, a percentage reported as activity, at one concentration (the size of the read-out at that concentration, not a potency): 52.8%
Compound 4: the middle estimate sits 14.8 percentage points below what was measured; the whole stated range lies below it.
By their numbers in this assay, from the lowest: compounds 2 and 1 (each within the scatter of the next); then compounds 4 and 3 (each within the scatter of the next).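

In this assay, the step of a number 13.6 percentage points higher from compound 1 to compound 4 (beyond the scatter) shows that a gain beyond the scatter at this aromatic carbon does not rest on the carboxy of compound 3 alone, since 4-methoxyphenyl, with no net charge, also gives one. Carboxy and 4-methoxyphenyl are not separated here, with a number 4.2 percentage points lower from compound 3 to compound 4 (within the scatter), whereas the step of a number 20.4 percentage points higher from compound 2 to compound 4 (beyond the scatter) separates 4-methoxyphenyl from ethoxycarbonyl, so the earlier contrast between compound 2 and compound 3 no longer sets the carboxy apart from every other group at this carbon. Nothing at hand accounts for the difference between these groups.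

The compounds shown do not tell whether the step to compound 4 comes with the six-membered aromatic ring of carbon itself or needs its methoxy, a question that an unsubstituted phenyl or a 4-hydroxyphenyl at the same carbon would address. Also open, from the compounds shown here alone, is how an amine or a longer alkyl chain at this carbon would read in this assay, and how any of these groups behaves at a concentration other than the single one tested.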